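Cyclopentyl for isopropyl across two related cores

This account rests on a few compounds, and the source may have more. Where it says the series, first, only, none or still open, it means among the compounds named here.

Measured so far in an assay on HEK293 cells for positive allosteric modulation of metabotropic glutamate receptor 2 (Rattus norvegicus), read by thallium flux, with a stated time of 2.5 min; a higher number here means that more compound is needed for the effect, a lower number that less compound is needed:
compound 1 `Cc1c(OCCCCOc2ccc(C(=O)O)cc2Cl)ccc(C(=O)CC2CCCC2)c1O` gives 237 nM
compound 2 `Cc1c(OCCCCOc2ccc(C(=O)O)cc2Cl)ccc(C(=O)CC(C)C)c1O` gives 96 nM
compound 3 `Cc1ccc(C(=O)O)cc1OCCCCOc1ccc(C(=O)CC(C)C)c(O)c1C` gives 454 nM

The change from compound 2 to compound 1 is cyclopentyl in place of isopropyl on a saturated chain carbon bound to a carbonyl carbon. It made a 2.5-fold higher number from compound 2 to compound 1 (0.39 log units; beyond the scatter). The cores of compound 2 and compound 3 differ by 5-carboxy-2-methylphenyl in place of 4-carboxy-2-chlorophenyl on an oxygen on a saturated carbon, and that change made a 4.7-fold higher number from compound 2 to compound 3 (0.67 log units; beyond the scatter). Compound 4 `Cc1ccc(C(=O)O)cc1OCCCCOc1ccc(C(=O)CC2CCCC2)c(O)c1C` is not yet measured; its difference from compound 3 is cyclopentyl in place of isopropyl on a saturated chain carbon bound to a carbonyl carbon, the same change at the same place as before, now on the core of compound 3. On the strength of that single earlier case, a step of similar size is expected, a 2.4-fold higher number from compound 3 to compound 4 (0.38 log units; beyond the scatter), to be read beside a 2.5-fold higher number from compound 2 to compound 1 (0.39 log units; beyond the scatter). Within the data shown here, compound 4 is therefore expected to give about 1100 nM in this assay, plausibly between 450 nM and 2700 nM, the width reflecting that only one prior instance of the change is known.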

Compound 4, half-maximal effective concentration: 1290 nM
Compound 4: middle estimate off by 1.2-fold (0.07 log units), on the low side; the measured number falls inside the stated range.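

Cyclopentyl in place of isopropyl gives a 2.8-fold higher number from compound 3 to compound 4 (0.45 log units; beyond the scatter) in this assay, matching the step on the other core: the same change on two cores in this assay, a 2.5-fold higher number (0.39 log units; beyond the scatter) from compound 2 to compound 1 and a 2.8-fold higher number (0.45 log units; beyond the scatter) from compound 3 to compound 4, 1.2-fold (0.06 log units) apart, within the scatter of two such steps

5-Carboxy-2-methylphenyl in place of 4-carboxy-2-chlorophenyl gives a 5.4-fold higher number from compound 1 to compound 4 (0.74 log units; beyond the scatter), and this change also holds its size whichever of the two groups is present: the same change on two cores in this assay, a 4.7-fold higher number (0.67 log units; beyond the scatter) from compound 2 to compound 3 and a 5.4-fold higher number (0.74 log units; beyond the scatter) from compound 1 to compound 4, 1.2-fold (0.06 log units) apart, within the scatter of two such steps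

These four compounds show that the two changes behave independently for this one pair of cores and this one read-out; they do not show that this extends to any other core, nor why either change raises the number.

Left open is whether a cyclohexyl or phenyl group in that place would follow the same step. Also open, on these data alone, is whether an amide or tetrazole in place of the carboxylic acid would preserve this independence.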